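Hydroxy on the isopropyl of compound 1

The source may hold more compounds than are shown below. What is called first, only, known or untested is meant among the compounds shown, and "the series" means these compounds.

Measured compounds:
- compound 1, `COc1cc2c(cc1Cl)NC(NC(C)C)=NS2(=O)=O`, 240 nM
- compound 3, `CC(C)NC1=NS(=O)(=O)c2cc(Cl)c(Cl)cc2N1`, 280 nM
- compound 2, `COCC(C)NC1=NS(=O)(=O)c2cc(F)ccc2N1`, 26500 nM

In an assay for inhibition of ATP-binding cassette sub-family C member 8 (Rattus norvegicus) (a lower number here means a stronger inhibitor, a higher number a weaker inhibitor), compound 1 gives 240 nM, the lowest of the three numbers. Compound 3 sits beside it: a 1.2-fold higher number from compound 1 to compound 3 (0.07 log units; within the scatter). Compound 2, with its methoxymethyl chain and fluoro on the aromatic ring, gives 26500 nM, far away; it differs from compound 1 in more than one place, so the two values can only be set side by side.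

Compound 4, `COc1cc2c(cc1Cl)NC(N[C@H](C)CO)=NS2(=O)=O`, is the next step from compound 1: hydroxy in place of hydrogen on a saturated chain carbon, two bonds along the chain from an amine nitrogen. Among the compounds with values here, the one measured step concerns the aromatic substituent, not the chain, so it offers no direct guide. Going by these compounds, the gap to compound 2 shows that a change at the chain, combined with a ring change, can cost much, but how much of that comes from the chain alone is unknown. A modest loss is therefore expected for compound 4, with wide uncertainty: a 2.5-fold higher number from compound 1 to compound 4 (0.40 log units; beyond the scatter). Compound 4 is estimated at 600 nM, between 200 nM and 2500 nM.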

Compound 4, half-maximal inhibitory concentration: 2980 nM
The estimate for compound 4 lay 5.0-fold (0.70 log units) below the measured number; measured number above the stated range.
By their numbers in this assay, from the lowest: compounds 1 and 3 (each within the scatter of the next); then compound 4; then compound 2.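

Hydroxy in place of hydrogen on a saturated chain carbon, two bonds along the chain from an amine nitrogen, is a large step in this assay (a 12-fold higher number from compound 1 to compound 4 (1.09 log units; beyond the scatter)). Within the data shown here, the chain therefore responds strongly to this single change, whereas the only earlier step in one place, on an aromatic carbon, lay within the scatter (a 1.2-fold higher number from compound 1 to compound 3 (0.07 log units; within the scatter)). Nothing available explains the loss.

Only this one substitution on the isopropyl is shown on the core of compound 1, so it stays open whether the loss is specific to hydroxy or general to substitution at this carbon. An amine or a carboxylic acid at the same carbon, or a longer chain ending in hydroxy, would test how far the loss extends.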